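Chloro in Place of Fluoro: Estimating Compound 4

The compounds below may be only part of what the source reports. "The series", "measured", "known", "first", "only" and "open" are said of these compounds alone.

Measured compounds:
Compound 1, `Cc1ccc(-n2nc(-c3ccccc3)nc2CNc2ccc(C(=O)NO)cc2)cc1`, gives 60.7% in an assay on Sf9 cells for inhibition of protein deacetylase HDAC6 (Homo sapiens), read by fluorescence, with a stated time of 40 min, tested at 100 nM; a lower number here means less inhibition, a higher number more inhibition at the concentration tested (going by the name of the read-out).
Compound 2, `O=C(NO)c1ccc(NCc2nc(-c3ccccc3)nn2-c2ccc(Br)cc2)cc1`, gives 65.9% in this assay.
Compound 3, `O=C(NO)c1ccc(NCc2nc(-c3ccccc3)nn2-c2ccc(F)cc2)cc1`, gives 67.6% in this assay.

Compound 3 holds the largest of the three numbers, but neither gap separates it from its neighbours: a number 1.7 percentage points higher from compound 2 to compound 3 (within the scatter) and a number 6.9 percentage points higher from compound 1 to compound 3 (within the scatter) are both within the scatter, so the three compounds are indistinguishable on these data.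

Compound 4, `O=C(NO)c1ccc(NCc2nc(-c3ccccc3)nn2-c2ccc(Cl)cc2)cc1`, has not yet been measured. It differs from compound 3 in one place: chloro in place of fluoro on an aromatic carbon. All three measured steps concern the same aromatic carbon and the same kind of exchange. Methyl to bromo gave a number 5.2 percentage points higher from compound 1 to compound 2 (within the scatter), methyl to fluoro gave a number 6.9 percentage points higher from compound 1 to compound 3 (within the scatter), and bromo to fluoro gave a number 1.7 percentage points higher from compound 2 to compound 3 (within the scatter); none exceeded the scatter. Fluoro to chloro is a smaller change than any of these, and no measured step suggests that a halogen at this position moves the number beyond the scatter in either direction.

Compound 4 is therefore expected to sit close to compound 3, with an expected step of a number 1.6 percentage points lower from compound 3 to compound 4 (within the scatter). Compound 4 is estimated to give 66% in this assay, within a range from 56% to 76%.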

Compound 4, a percentage reported as inhibition, at one concentration (the size of the read-out at that concentration, not a potency): 55.4%
Beside the measured number, compound 4's estimate is 10.6 percentage points above it; the whole stated range lies above it.
By their numbers in this assay, from the lowest: compounds 4, 1, 2 and 3 (each within the scatter of the next, the first and the last beyond it).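

In this assay, among these compounds, exchanging one halogen for another at this aromatic carbon, para to a large group, is not always a neutral change: the step to chloro gives a number 12.2 percentage points lower from compound 3 to compound 4 (beyond the scatter) and likewise a number 10.5 percentage points lower from compound 2 to compound 4 (beyond the scatter), the first steps to pass the scatter. Chloro thus stands apart from both fluoro and bromo, although those two could not be told apart from each other, so among these three halogens the number does not follow the order of the atoms down the halogen group, and the chloro compound does not separate from the methyl compound, with a number 5.3 percentage points lower from compound 1 to compound 4 (within the scatter) as the step. The data given include no independent measurement that would account for chloro parting from its two fellow halogens at this carbon.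

Whether chloro is a lone exception remains open, since only methyl, fluoro, chloro and bromo are shown here, and an iodo, methoxy, nitrile or amine group on the same carbon would show how far the number moves with other substituents. Also open, from the compounds shown here alone, is whether the gap would persist across a range of concentrations, as this read-out comes from a single concentration and gives no potency.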